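The source may hold more compounds than are shown below. What is called first, only, known or untested is meant among the compounds shown, and "the series" means these compounds.

Measured compounds in a functional assay on B16-F10 cells (Mus musculus) for inhibition, read by MTT assay, with a stated time of 72 h; on this read-out lower numbers stand for stronger inhibition and higher numbers for weaker inhibition:
- compound 1, `CC(C)c1ccc(-c2nc(SCc3cn(CC(=O)NC(=O)Nc4ccccn4)nn3)nc(Nc3cccc(C(F)(F)F)c3)c2C#N)cc1`: 1700 nM
- compound 2, `CC(C)c1ccc(-c2nc(SCc3cn(CC(=O)NC(=O)Nc4ccccn4)nn3)nc(Nc3cccc([N+](=O)[O-])c3)c2C#N)cc1`: 26400 nM
- compound 3, `Cc1ccc(Nc2nc(SCc3cn(CC(=O)NC(=O)Nc4ccccn4)nn3)nc(-c3ccc(C(C)C)cc3)c2C#N)cc1`: 3060 nM

Compound 2 gives the highest number of the three. Its nearest neighbour is compound 3, reached by an 8.6-fold lower number from compound 2 to compound 3 (0.94 log units; beyond the scatter); the furthest is compound 1, from which compound 2 is reached by a 16-fold higher number from compound 1 to compound 2 (1.19 log units; beyond the scatter). Compound 1 and compound 3 differ from each other by a 1.8-fold higher number from compound 1 to compound 3 (0.26 log units; within the scatter), so the two compounds without the nitro group sit together, and the nitro compound stands apart.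

The step now considered leads to compound 4, `Cc1cccc(Nc2nc(SCc3cn(CC(=O)NC(=O)Nc4ccccn4)nn3)nc(-c3ccc(C(C)C)cc3)c2C#N)c1`. The change from compound 2 is methyl in place of nitro on an aromatic carbon. The nitro group is thus removed again, as it is in the step from compound 2 to compound 3, and the methyl that enters is the same group carried by compound 3 on its phenyl ring. Both measured steps that involve compound 2 bear on this change and both are large; the expectation in this assay is therefore a step downward, well beyond the scatter, of about the size seen toward compound 3, namely an 11-fold lower number from compound 2 to compound 4 (1.02 log units; beyond the scatter). Compound 4 is estimated at 2500 nM, with a range from 1000 nM to 6500 nM.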

Compound 4, half-maximal inhibitory concentration: 1650 nM
The estimate for compound 4 lay 1.5-fold (0.18 log units) above the measured number, and the stated range covers the measured number.
By their numbers in this assay, from the lowest: compounds 4, 1 and 3 (each within the scatter of the next); then compound 2.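

In this assay, the step (a 16-fold lower number from compound 2 to compound 4 (1.20 log units; beyond the scatter)) shows that the high number of compound 2 is lost again when 3-nitrophenyl gives way to 3-methylphenyl, with the substituent kept on the same ring carbon, so among the four compounds only the nitro compound stands apart. At this place, methyl and trifluoromethyl cannot be told apart (a 1.0-fold lower number from compound 1 to compound 4 (0.01 log units; within the scatter)), and neither can 3-methylphenyl and 4-methylphenyl (a 1.9-fold lower number from compound 3 to compound 4 (0.27 log units; within the scatter)), so compounds 1, 3 and 4 form a single group in which no order can be read. No measurement on hand accounts for the separation of the nitro compound from the other three.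

From the compounds shown here alone, it remains open whether an amine, a methoxy group or a carboxylic acid in place of nitro on this aromatic carbon would sit with compound 2 or with compounds 1, 3 and 4. Going by these compounds, it also remains open whether the gap between nitro and methyl would persist with a group other than the nitrile on the shared core.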